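The source may hold more compounds than are shown below. What is called first, only, known or untested is meant among the compounds shown, and "the series" means these compounds.

Among the measured compounds shown here, compound 1, with the structure `C=C1C(=O)[C@]23C[C@@]1(O)CC[C@H]2c1ccc(O)c(C)c1[C@@H]3Cn1cc(-c2ccc(C(F)(F)F)cc2)nn1`, is the one compound here with a numerical result in a functional assay on MCF7 cells (Homo sapiens) for cytotoxicity, read by MTT assay, with a stated time of 4 days (a higher number here means a weaker inhibitor, a lower number a stronger inhibitor), where compound 1 gives 1840 nM. Compound 2, with the structure `Cc1ccc(-c2cn(C[C@H]3c4c(ccc(OS(=O)(=O)c5ccc(C)cc5)c4C)[C@@H]4CC[C@@]5(C)C[C@]43CC5=O)nn2)cc1`, is recorded in this assay only as a limit, > 20000 nM, not as a number, which is the situation described by the limit of > 20000 nM in this assay, at which 1 of the 2 values shown sits. Compound 3, with the structure `C=C1C(=O)[C@]23C[C@@]1(O)CC[C@H]2c1ccc(O)c(C)c1[C@@H]3Cn1cc(-c2ccccn2)nn1`, has not yet been measured in this assay. It differs from compound 1 in one place: pyridin-2-yl in place of 4-(trifluoromethyl)phenyl on an aromatic carbon. For the measured compounds named here, no pair of measured compounds differs in just this way, so no measured step shows what this change does. The expectation is a modest weakening, a step from compound 1 to compound 3 of about a 1.9-fold higher number from compound 1 to compound 3 (0.28 log units; within the scatter), which is only slightly beyond the usual scatter of repeated measurements. Compound 3 is therefore estimated to give 3500 nM in this assay, within a range of 1200 nM to 10000 nM.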

Compound 3, half-maximal inhibitory concentration: 2240 nM
Estimate against measurement, compound 3: 1.6-fold (0.19 log units) above, within the range that was stated.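

Measured in this assay the change at this position gives a 1.2-fold higher number from compound 1 to compound 3 (0.09 log units; within the scatter) and so the values of the two compounds cannot be told apart. This one pair shows that 4-(trifluoromethyl)phenyl, on the aromatic carbon of the five-membered aromatic ring with 3 nitrogen, can give way to pyridin-2-yl, which has fewer heavy atoms and a hydrogen-bond acceptor, without a change that stands out from the scatter in this cell assay. Nothing measured here gives a reason for this outcome.

The compounds shown include no amine, carboxylic acid or longer alkyl chain at this position, so how such groups would read in this assay stays open. A plain phenyl ring is also absent, which leaves the part played by the trifluoromethyl group and that of the ring nitrogen unseparated.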